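The source may report more compounds than this note shows. Statements on the series, on what has been measured and on what is new or still open speak of the compounds shown alone.

Measured so far:
- compound 1 `CCOC(=O)c1c(C)noc1OCC(=O)[C@H](CC(=O)O)NC(=O)[C@@H](NC(=O)COc1cccc2ccccc12)C(C)C`: > 200000 nM
- compound 2 `CC(C)[C@H](NC(=O)COc1cccc2ccccc12)C(=O)N[C@@H](CC(=O)O)C(=O)CSC1=NCCS1`: > 200000 nM
- compound 3 `CC(C)[C@H](NC(=O)COc1cccc2ccccc12)C(=O)N[C@@H](CC(=O)O)C(=O)CSc1nc(-c2ccccc2)c(-c2ccccc2)o1`: > 200000 nM

In a functional assay on Jurkat cells (Homo sapiens) for inhibition (on this read-out higher numbers stand for weaker inhibition and lower numbers for stronger inhibition), compound 2 gives > 200000 nM, which is a limit of the assay and not a number. The same holds for compound 1 with > 200000 nM, also a limit. Compound 3 likewise reaches only > 200000 nM, again a limit. Thus every value shown sits at the limit of > 200000 nM in this assay, at which 3 of the 3 values shown sit, and no compound in the series has a readable number. Among the measured compounds shown here, the one step between measured compounds, a step that the two limits leave unreadable from compound 1 to compound 2, cannot be read for the same reason, so nothing here tells how a change on the chain carbon bound to the carbonyl shifts inhibition.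

Compound 4 `CC(C)[C@H](NC(=O)COc1cccc2ccccc12)C(=O)N[C@@H](CC(=O)O)C(=O)CSc1nnnn1C` differs from compound 2 by a group of 6 heavy atoms (2 carbon, 4 nitrogen; one five-membered aromatic ring with 4 hetero atoms) in place of a group of 5 heavy atoms (3 carbon, 1 nitrogen, 1 sulfur; one five-membered non-aromatic ring with 2 hetero atoms), on a sulfur. For the measured compounds named here, no measured step bears on this exchange on the sulfur, and all three measured values are limits, so no direction can be read. For compound 4 the expected step is a step that the limit leaves unreadable from compound 2 to compound 4, essentially none beyond the scatter, with a further limit the likeliest outcome. For compound 4 the estimate is 300000 nM, ranging from 100000 nM to 2000000 nM.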

Compound 4, half-maximal inhibitory concentration: > 200000 nM
Compound 4: a limit, no number; the forecaster's own chance of this, stated with the estimate: 85%; the middle value lies beyond the limit too.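

Compound 4 gives > 200000 nM, a limit and not a number. The steps from compound 1 and compound 2 to compound 4 therefore cannot be read: the limit of > 200000 nM in this assay, at which 4 of the 4 values shown sit.

From the compounds shown here alone, whether any group on the sulfur gives a readable inhibition value stays open.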